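The compounds below may be only part of what the source reports. "The series", "measured", "known", "first", "only" and "open" are said of these compounds alone.

Measured so far:
Compound 1, `CNC(=O)c1cncc(NS(=O)(=O)c2cc(Cl)ccc2OC)c1`; in an assay on isolated protein for inhibition of alkaline phosphatase, tissue-nonspecific isozyme (Homo sapiens) (a lower number here means a stronger inhibitor, a higher number a weaker inhibitor), compound 1 gives > 20000 nM, which is a limit of the assay and not a number.
Compound 2, `COc1ccc(Cl)cc1S(=O)(=O)Nc1cncc(-c2ccccc2C)c1`; in this assay compound 2 gives "not determined" (no result reported).

Where compound 2 stands: no number exists for it in this assay. Among the compounds with values here, the only other value is the limit of > 20000 nM in this assay, at which 1 of the 2 values shown sits, so compound 2 has no measured anchor on either side.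

Compound 3, `COc1ccc(Cl)cc1S(=O)(=O)Nc1cncc(C(=O)O)c1`, follows from compound 2 by carboxy in place of 2-methylphenyl on an aromatic carbon. Within the data shown here, no step between measured compounds covers this change, and compound 2 itself carries no number, so neither size nor direction of the step in this assay can be read from the data. Among the measured compounds shown here, the one value, the limit of > 20000 nM in this assay, at which 1 of the 2 values shown sits, for compound 1, points toward weak inhibition for the whole set, and compound 3 is expected to fall in the same region, most likely again as a limit rather than a number. Compound 3 is estimated at 20000 nM in this assay, with a range of 5000 nM to 60000 nM.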

Compound 3, half-maximal inhibitory concentration: > 20000 nM
Compound 3: a limit, no number; the forecaster's own chance of this, stated with the estimate: 65%; the middle value lies on the limit itself.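

No step can be read from compound 1 to compound 3: each carries only a limit of the assay in this assay, not a number. The compounds shown leave open how far hydroxy in place of methylamino on a carbonyl carbon shifts inhibition, and whether any compound in this series gives a numerical value in this assay.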